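This account rests on a few compounds, and the source may have more. Where it says the series, first, only, none or still open, it means among the compounds named here.

Compound 3 `NC(=O)C1CCN(c2nc(-c3cc(F)c(Cl)cc3F)nc3c2CS(=O)(=O)C3)CC1` carries a carbamoyl group on a saturated ring carbon of its six-membered ring. Within the data shown here, in a physicochemical assay for solubility, with a stated time of 20 h, at pH 6.8 (a lower number here means a less soluble compound, a higher number a more soluble compound), compound 3 gives 40000 nM, the highest of the three numbers measured so far, and its steps to both companions lie beyond the scatter, so it is the most soluble of the three. Compound 1 `O=S1(=O)Cc2nc(-c3cc(F)c(Cl)cc3F)nc(N3CCC(CO)CC3)c2C1` carries a hydroxymethyl group on that ring carbon and gives 16000 nM in this assay. Compound 2 `NC(=O)CC1CCN(c2nc(-c3cc(F)c(Cl)cc3F)nc3c2CS(=O)(=O)C3)CC1` carries a carbamoylmethyl group there and gives 15000 nM. The steps of a 2.5-fold higher number from compound 1 to compound 3 (0.40 log units; beyond the scatter) and a 2.7-fold higher number from compound 2 to compound 3 (0.43 log units; beyond the scatter) set compound 3 apart, whereas a 1.1-fold lower number from compound 1 to compound 2 (0.03 log units; within the scatter).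

Compound 4 `NC(=O)CCC1CCN(c2nc(-c3cc(F)c(Cl)cc3F)nc3c2CS(=O)(=O)C3)CC1` takes the next step: 2-carbamoylethyl in place of carbamoyl on a saturated ring carbon. The amide is kept, but pushed out onto a chain of three carbons. The comparison that bears on this is a 2.7-fold higher number from compound 2 to compound 3 (0.43 log units; beyond the scatter): read backwards, inserting a single carbon between the ring and the amide went with a modestly lower number. A two-carbon spacer is therefore expected to land on the same side, by a similar or slightly larger margin. Compound 4 is expected to give about 12000 nM in this assay, within a range from 5000 nM to 30000 nM, which amounts to an expected 3.3-fold lower number from compound 3 to compound 4 (0.52 log units; beyond the scatter).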

Compound 4, solubility: 8000 nM
Beside the measured number, compound 4's estimate is 1.5-fold (0.18 log units) above it; measured number inside the range.
By their numbers in this assay, from the lowest: compounds 4, 2 and 1 (each within the scatter of the next); then compound 3.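

In this assay, the widest step among these compounds is a 5.0-fold lower number from compound 3 to compound 4 (0.70 log units; beyond the scatter), which shows that keeping the amide but moving it out on a 2-carbamoylethyl chain costs more than the shorter carbamoylmethyl chain did. Extending the chain further, however, gives no separable result, since the comparison with the carbamoylmethyl compound reads a 1.9-fold lower number from compound 2 to compound 4 (0.27 log units; within the scatter). The comparison with the hydroxymethyl compound is also within the scatter, at a 2.0-fold lower number from compound 1 to compound 4 (0.30 log units; within the scatter), so compounds 1, 2 and 4 form one group, and only compound 3, with the carbamoyl on the saturated ring carbon itself, stands apart. Nothing available here explains why the numbers fall this way.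

The compounds shown leave open whether an amine or a carboxylic acid on this same ring carbon would stand with compound 3 or with the other three. They also leave open whether a longer chain ending in the amide, or a hydroxy group on a 2-carbon chain, would stay with that group.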